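A few compounds are considered here, and "the series" means these few. Any claim that something is new, unique, unknown or untested is made for them only; others in the source may bear on it.

Of the compounds shown here, two built on one shared core have been tested in a functional assay on cells (Leukemia cell, Homo sapiens) for cytotoxicity, with a stated time of 48 h; on this read-out lower numbers stand for stronger inhibition of growth and higher numbers for weaker inhibition of growth. Compound 1, `COc1cc2c(/C=C3/C(=O)Nc4ccc(O)cc43)c(Cl)n(Cc3cc(OC)c(OC)c(OC)c3)c2cc1C`, gives 18600 nM. Compound 2, `COc1cc2c(cc1C)NC(=O)/C2=C/c1c(Cl)n(Cc2cc(OC)c(OC)c(OC)c2)c2cc(C)c(OC)cc12`, gives 42700 nM, the higher of the two numbers and therefore the weaker growth inhibition; its gap to compound 1 lies beyond the usual scatter of repeated measurements. Compound 3, `COc1ccc2c(c1)/C(=C\c1c(Cl)n(Cc3cc(OC)c(OC)c(OC)c3)c3cc(C)c(OC)cc13)C(=O)N2`, has not yet been measured. It differs from compound 2 in a single place: hydrogen in place of methyl on an aromatic carbon. Going by the values given here, no comparison between measured compounds shows what this particular change does on this core, so the expectation rests only on how small the change is, a methyl group swapped for a hydrogen atom while everything else stays the same. For the step from compound 2 to compound 3 a change of a 1.1-fold lower number from compound 2 to compound 3 (0.03 log units; within the scatter) is expected, which would keep the value close to that of compound 2 and inside the scatter, with the direction uncertain. The estimate for compound 3 is 40000 nM, with a range from 15000 nM to 100000 nM.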

Compound 3, concentration for total growth inhibition: 77600 nM
Compound 3: middle estimate off by 1.9-fold (0.29 log units), on the low side, within the range that was stated.
By their numbers in this assay, from the lowest: compound 1; then compounds 2 and 3 (each within the scatter of the next).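

In this assay, hydrogen in place of methyl on an aromatic carbon gives a 1.8-fold higher number from compound 2 to compound 3 (0.26 log units; within the scatter), so at this place on the shared core the two compounds cannot be told apart, and this methyl group shows no clear contribution to growth inhibition. Compound 3 also makes a second single change readable, methyl in place of hydrogen on an oxygen on an aromatic ring, which gives a 4.2-fold higher number from compound 1 to compound 3 (0.62 log units; beyond the scatter). This modest step to a higher number means weaker growth inhibition with the methyl on that oxygen. The difference lies beyond the usual scatter of repeated measurements. No measurement offered here accounts for either result.

A single swap between methyl and hydrogen says little about how this aromatic carbon would respond to something quite different, such as an amine, a chlorine atom or a longer chain like propyl. On these data alone, it also remains open whether the oxygen would respond in the same way to a larger group there, such as ethyl or a chain ending in a carboxylic acid.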